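Pyridinyl Extension of the Allyl Chain in HeLa Cytotoxicity

The compounds below may be only part of what the source reports. "The series", "measured", "known", "first", "only" and "open" are said of these compounds alone.

Compound 2 `C=CC[C@H]1C[C@@H]([C@@H](O)c2ccccc2)CO[C@@H]1c1ccccc1` gives 25400 nM in a functional assay on HeLa cells (Homo sapiens) for cytotoxicity, read by WST assay, with a stated time of 48 h (on this read-out higher numbers stand for weaker inhibition and lower numbers for stronger inhibition), the highest of the two numbers shown, while compound 1 `COc1ccc(/C=C/C[C@H]2C[C@@H]([C@@H](O)c3ccc(OC)c(OC)c3)CO[C@@H]2c2ccccc2)cc1OC` gives 17000 nM in this assay, a gap that lies within the scatter. Compound 3 `O[C@@H](c1ccccc1)[C@H]1CO[C@H](c2ccccc2)[C@@H](C/C=C/c2ccncc2)C1` has not been measured. It differs from compound 2 in one place: 2-(pyridin-4-yl)ethenyl in place of vinyl on a saturated chain carbon bound to a saturated ring carbon. Among the measured compounds shown here, no step between measured compounds covers this change, so the expectation rests on compound 1, which also carries an aromatic ring on its chain. The step of a 1.7-fold lower number from compound 2 to compound 3 (0.23 log units; within the scatter) is expected to be small, toward a lower number, or none beyond the scatter. Compound 3 is estimated at 15000 nM, with a range of 5000 nM to 40000 nM.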

Compound 3, half-maximal inhibitory concentration: > 100000 nM
Compound 3 gave a limit, no number; the forecaster's own chance of this, stated with the estimate: 10%; middle value at least 6.6-fold (0.82 log units) away from the limit.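

In this assay compound 3 gives a limit and not a number: the limit of > 100000 nM in this assay, at which 1 of the 3 values shown sits. Even so, the step can be read: 2-(pyridin-4-yl)ethenyl in place of vinyl on a saturated chain carbon bound to a saturated ring carbon gives an at least 3.9-fold higher number from compound 2 to compound 3 (0.59 log units; beyond the scatter). Among the compounds shown here, this is the first step read at this position, and it shows that the position responds to this change, toward weaker inhibition. Open, on these data alone, is whether this follows from the pyridine nitrogen or from the extended chain itself. A plain phenyl group on the same chain would separate the two.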